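The source may report more compounds than this note shows. Statements on the series, on what has been measured and on what is new or still open speak of the compounds shown alone.

Compound 1 `O=C(N/N=C/c1ccccc1)c1cnccn1` is the parent of this small set of hydrazone carboxamides. In an ADME assay on J774 cells (Mus musculus) for cytotoxicity, read by MTT assay, with a stated time of 48 h, tested at 100 ug/mL (on this read-out lower numbers stand for a stronger effect and higher numbers for a weaker effect at the one concentration tested), compound 1 gives 75%, the lowest of the three numbers in hand, and the two substituted analogues sit above it by the same margin. Compound 2 `O=C(N/N=C/c1cccc(Cl)c1)c1cnccn1` gives 100% and compound 3 `COc1ccccc1/C=N/NC(=O)c1cnccn1` gives 100%; the step of a number 25 percentage points higher from compound 1 to compound 2 (beyond the scatter) and the step of a number 25 percentage points higher from compound 1 to compound 3 (beyond the scatter) both go the same way and both lie beyond the scatter.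

The next compound, compound 4 `COc1ccc(/C=N/NC(=O)c2cnccn2)cc1`, is not yet measured. It differs from compound 1 as follows: methoxy in place of hydrogen on an aromatic carbon. The two measured steps bear directly on this change: one adds a methoxy on an aromatic carbon of the same ring, the other adds a different group to that ring, and each raised the number by a modest amount. The methoxy in compound 4 stands on a different carbon of that ring than in compound 3, so the match is not exact, but with nothing in the set pointing the other way a rise of similar size is expected, a number 20 percentage points higher from compound 1 to compound 4 (beyond the scatter). For compound 4 the estimate in this assay is 95%, expected to fall between 78% and 100%.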

Compound 4, a percentage reported as activity, at one concentration (the size of the read-out at that concentration, not a potency): 55%
Compound 4: middle estimate off by 40 percentage points, on the high side; the whole stated range lies above it.
By their numbers in this assay, from the lowest: compound 4; then compound 1; then compounds 2 and 3 (each within the scatter of the next).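

For the compounds shown here, with methoxy para to a large group, the change from hydrogen reads a number 20 percentage points lower from compound 1 to compound 4 (beyond the scatter), the only downward step in this set. Compound 3, with methoxy on another carbon of the same ring, gives 100% and compound 4 gives 55%, so in this assay the same group moves the number in opposite directions depending on its place on the ring. No measurement at hand accounts for this difference.

Going by these compounds, it remains open whether the lower number belongs to methoxy itself or to substitution at this carbon in general, a question that chloro, an amine or a longer chain such as ethoxy at the same place would address. The read-out at one concentration also leaves open how these differences would look across a range of concentrations.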